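A few compounds are considered here, and "the series" means these few. Any claim that something is new, unique, unknown or untested is made for them only; others in the source may bear on it.

Measured so far in a functional assay on HCT-116 cells (Homo sapiens) for antiproliferative activity, read by MTT assay, with a stated time of 72 h; on this read-out lower numbers stand for stronger inhibition of growth and higher numbers for weaker inhibition of growth:
- compound 1 `Cc1c(C(=O)Nc2ccc(SC#N)cc2)nnn1-c1ccc(C(C)C)cc1`: 8400 nM
- compound 2 `Cc1ccc(-n2nnc(C(=O)Nc3ccc(SC#N)cc3)c2C)cc1C`: > 100000 nM

Among the compounds with values here, compound 1 holds the only true number in this small set. For compound 2, the result > 100000 nM is a limit of the assay, not a number.

Compound 3 `COc1cccc(-n2nnc(C(=O)Nc3ccc(SC#N)cc3)c2C)c1` has not yet been measured. It keeps the core of compound 1 and changes one group: 3-methoxyphenyl in place of 4-isopropylphenyl on an aromatic nitrogen. Within the data shown here, only one measured step bears on this change, since it also replaces the 4-isopropylphenyl on an aromatic nitrogen. Putting 3,4-dimethylphenyl there gave an at least 11-fold higher number from compound 1 to compound 2 (1.07 log units; beyond the scatter), a large loss of growth inhibition. On the evidence of compound 2 alone, a step in the same direction is expected in this assay, probably a smaller one, though a single step is a thin guide. The expected change is a 3.6-fold higher number from compound 1 to compound 3 (0.55 log units; beyond the scatter). For compound 3 the estimate is 30000 nM, with an expected range of 9000 nM to 100000 nM.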

Compound 3, concentration for 50% growth inhibition: 39800 nM
Estimate against measurement, compound 3: 1.3-fold (0.12 log units) below, and the stated range covers the measured number.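

The 3-methoxyphenyl group also gives weaker growth inhibition than the 4-isopropylphenyl group in this assay, with a 4.7-fold higher number from compound 1 to compound 3 (0.68 log units; beyond the scatter). Compound 1 therefore stays the strongest of the three, but a change at this position need not remove measurable activity, as the comparison of the two replacement groups shows, with an at least 2.5-fold lower number from compound 2 to compound 3 (0.40 log units; beyond the scatter). Compound 2 holds a limit and not a number, so this second step gives only a minimum size: the limit of > 100000 nM in this assay, at which 1 of the 3 values shown sits.

Three groups on the aromatic nitrogen are too few to support a rule, and each replacement alters more than one feature of the group at once. On these data alone, how an unsubstituted phenyl group, or a butyl chain in place of the isopropyl, would behave at this position remains open.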